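A few compounds are considered here, and "the series" means these few. Any claim that something is new, unique, unknown or untested is made for them only; others in the source may bear on it.

Measured so far:
compound 1, `CC1(C)CC12NC(=O)NC2=O`, with 50%
compound 2, `CN1C(=O)NC2(CC2(C)C)C1=O`, with 90%

In a functional assay on the whole organism for inhibition, with Mus musculus as the target, in the maximal electroshock model, at a dose of 30 mg/kg by the oral route (on this read-out higher numbers stand for a stronger effect at the one dose given and lower numbers for a weaker effect), compound 1 gives 50%, and compound 2 gives 90%. Compound 2 stands highest of the two numbers, and its nearest neighbour is compound 1. Going by the values given here, the single measured step, a number 40 percentage points higher from compound 1 to compound 2 (beyond the scatter), is large and beyond the scatter; it came from a methyl in place of hydrogen on an amide-type nitrogen in a ring.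

Compound 3, `CC(C)N1C(=O)NC2(CC2(C)C)C1=O`, has not yet been measured. It differs from compound 2 as follows: isopropyl in place of methyl on an amide-type nitrogen in a ring. Among the compounds with values here, the measured step bears on this only loosely: it concerns the same nitrogen, but it went from hydrogen to methyl, whereas here a larger group replaces the methyl, and no measured step shows what that does. The step expected in this assay is therefore a number 10 percentage points lower from compound 2 to compound 3 (within the scatter), one that stays within the scatter, with a wide range. Compound 3 is expected to give 80%, somewhere between 45% and 100%.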

Compound 3, a percentage reported as inhibition, in the whole organism at one dose (the size of the read-out at that dose, not a potency): 70%
The estimate for compound 3 lay 10 percentage points above the measured number, within the range that was stated.
By their numbers in this assay, from the lowest: compound 1; then compound 3; then compound 2.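

In this assay, this ring nitrogen now has three different substituents to compare, and the number does not simply rise with the size of the group. Isopropyl in place of methyl gives a number 20 percentage points lower from compound 2 to compound 3 (beyond the scatter), so the larger group gives back part of the gain seen with methyl, yet isopropyl in place of hydrogen still gives a number 20 percentage points higher from compound 1 to compound 3 (beyond the scatter). No measurement is available to explain why the number falls again with isopropyl.

What an ethyl or a cyclopropyl group on this nitrogen would give remains open, so the compounds shown cannot tell where the number begins to fall beyond methyl. Also open, from the compounds shown here alone, is how a longer chain, or a chain ending in an amine or a carboxylic acid, would behave at this position.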